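This account rests on a few compounds, and the source may have more. Where it says the series, first, only, none or still open, it means among the compounds named here.

Compound 1 `COc1ccc(-c2cc3ccccc3nc2/C=C/C(=O)c2ccccc2)cc1` holds the lowest of the two numbers recorded in a functional assay on MDA-MB-231 cells (Homo sapiens) for antiproliferative activity, read by XTT assay, with a stated time of 72 h; a higher number here means a weaker inhibitor, a lower number a stronger inhibitor: compound 1 gives 860 nM. The other measured compound, compound 2 `COc1ccc(C(=O)/C=C/c2nc3ccccc3cc2-c2ccc(OC)cc2)cc1`, gives 7540 nM in this assay, and the step of an 8.8-fold higher number from compound 1 to compound 2 (0.94 log units; beyond the scatter) comes from a methoxy in place of hydrogen on an aromatic carbon. Compound 3 `COc1ccc(-c2cc3ccccc3nc2/C=C/C(=O)c2cccs2)cc1` has not yet been measured in this assay. It differs from compound 1 thus: thiophen-2-yl in place of phenyl on a carbonyl carbon. For the measured compounds named here, no measured step exchanges the ring on the carbonyl carbon; the single known step touches that ring only by adding a methoxy group, so it bears on the present change only loosely. With nothing closer to lean on, the step of a 1.2-fold higher number from compound 1 to compound 3 (0.07 log units; within the scatter) is expected to be small, possibly within the scatter, in either direction. The estimate for compound 3 is 1000 nM, with a range from 350 nM to 3000 nM.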

Compound 3, half-maximal inhibitory concentration: 410 nM
Estimate against measurement, compound 3: 2.4-fold (0.39 log units) above; measured number inside the range.
By their numbers in this assay, from the lowest: compound 3; then compound 1; then compound 2.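

In this assay, for the compounds shown here, the ring on the carbonyl carbon proves open to exchange, and not only to substitution: thiophen-2-yl in place of phenyl gives a 2.1-fold lower number from compound 1 to compound 3 (0.32 log units; beyond the scatter), the first step here that lowers the number. Set against the 4-methoxyphenyl group on the same carbon, thiophen-2-yl gives an 18-fold lower number from compound 2 to compound 3 (1.26 log units; beyond the scatter), so among the three groups at this position compound 3 holds the lowest number, with both of its steps beyond the scatter. Nothing available explains why the thiophen-2-yl group does better at this position.

The compounds shown cannot separate the contribution of the sulfur atom from that of the five-membered ring, a question that furan-2-yl or thiophen-3-yl would address. They also leave open whether a methoxy group on the thiophene ring would raise the number as it does on the phenyl ring.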